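A few compounds are considered here, and "the series" means these few. Any claim that something is new, unique, unknown or untested is made for them only; others in the source may bear on it.

Compound 1 `Nc1ncnn2c([C@@H]3O[C@H](CO)[C@@H](O)[C@H]3O)cc(C#CC3CC3)c12` is the reference point of this small set. In a functional assay on LN-229 cells (Homo sapiens) for antiproliferative activity, with a stated time of 72 h (on this read-out lower numbers stand for stronger inhibition and higher numbers for weaker inhibition), compound 1 gives 30 nM, the lowest of the two numbers shown. Compound 2 `Nc1ncnn2c([C@@H]3O[C@H](CO)[C@@H](O)[C@H]3O)cc(C#Cc3ccc(F)cc3)c12` carries 4-fluorophenyl on the triple-bonded carbon in place of cyclopropyl. In this assay compound 2 reaches only the limit of the measurement, > 100000 nM. Compound 3 `Nc1ncnn2c([C@@H]3O[C@H](CO)[C@@H](O)[C@H]3O)cc(-c3ccccc3)c12` has phenyl directly on the aromatic carbon. In this assay compound 3 gives 75100 nM. The two steps away from compound 1 are both large: an at least 3300-fold higher number from compound 1 to compound 2 (3.52 log units; beyond the scatter) and a 2500-fold higher number from compound 1 to compound 3 (3.40 log units; beyond the scatter). Between the two aryl compounds the difference is small, an at least 1.3-fold lower number from compound 2 to compound 3 (0.12 log units; that floor lies within the scatter); the limit of > 100000 nM in this assay, at which 1 of the 3 values shown sits, caps what can be said of compound 2.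

Compound 4 `Nc1ncnn2c([C@@H]3O[C@H](CO)[C@@H](O)[C@H]3O)cc(-c3ccoc3)c12` is not yet measured. Relative to compound 1 the change is furan-3-yl in place of 2-cyclopropylethynyl on an aromatic carbon. Both measured replacements of the 2-cyclopropylethynyl group by an aromatic ring, whether through a triple bond or directly on the aromatic carbon, cost a large step in this assay, and compound 4 places a five-membered aromatic ring directly on that carbon, as phenyl sits in compound 3. A large increase in the number is therefore expected, a 670-fold higher number from compound 1 to compound 4 (2.82 log units; beyond the scatter). For compound 4 the estimate in this assay is 20000 nM, in the range 2000 nM to 150000 nM.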

Compound 4, half-maximal inhibitory concentration: 1000 nM
Compound 4: the middle estimate sits 20-fold (1.30 log units) above what was measured; measured number outside the range, below it.
By their numbers in this assay, from the lowest: compound 1; then compound 4; then compound 3. At a limit, above all of these: compound 2.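

In this assay, an aromatic ring set directly on this carbon is not uniformly poor: replacing phenyl with furan-3-yl gives a large gain, a 75-fold lower number from compound 3 to compound 4 (1.88 log units; beyond the scatter), so the identity of the ring matters at this position. Even so, furan-3-yl does not match 2-cyclopropylethynyl, although the two groups are equal in heavy-atom count, and the remaining gap is large: a 33-fold higher number from compound 1 to compound 4 (1.52 log units; beyond the scatter). The step of an at least 100-fold lower number from compound 2 to compound 4 (2.00 log units; beyond the scatter) is a floor only, since it starts from a limit and not from a number: the limit of > 100000 nM in this assay, at which 1 of the 4 values shown sits.

As far as these compounds go, whether the gain over phenyl follows the ring oxygen of furan-3-yl or the five-membered ring itself stays open, and a thiophen-3-yl group on the same carbon would help separate the two. Also open, from the compounds shown here alone, is whether the triple bond or the three-membered ring carries most of the strength of compound 1, which a 2-cyclopropylethyl chain or a cyclopropyl group set directly on this carbon would test.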